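The compounds below may be only part of what the source reports. "The series", "measured", "known", "first", "only" and "open" are said of these compounds alone.

Working notes on the series. Two compounds of the shared core have been run in an assay on CHO cells for displacement of a labelled ligand from adenosine receptor A1 (Homo sapiens), read by radioligand binding; a lower number here means a stronger inhibitor, a higher number a weaker inhibitor. Within the data shown here, compound 2 `O=c1oc2c(O)cccc2cc1-c1ccccc1` is the one member with a numerical result: in this assay compound 2 gives 4620 nM. Compound 1 `O=c1oc2c(O)cccc2cc1-c1ccc(Br)cc1` returns only a limit of the assay, > 100000 nM, and not a number. Among the measured compounds shown here, the single step between the measured pair is an at least 21-fold lower number from compound 1 to compound 2 (1.33 log units; beyond the scatter); since compound 1 sits at the limit of > 100000 nM in this assay, at which 1 of the 2 values shown sits, the true size of that step is not fixed, only its floor. Compound 3 `O=c1oc2c(O)c(O)ccc2cc1-c1ccccc1` is not yet measured. Relative to compound 2 the change is hydroxy in place of hydrogen on an aromatic carbon. For the measured compounds named here, the one measured step concerns the pendant phenyl ring, not the fused ring that is altered here, so it offers no direct guide to the new step, and nothing among the measured compounds speaks for a large move in either direction. The expectation for compound 3 in this assay is therefore a step of about a 1.2-fold lower number from compound 2 to compound 3 (0.06 log units; within the scatter), within the scatter. On that basis compound 3 is estimated at 4000 nM, with a range from 1000 nM to 16000 nM.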

Compound 3, inhibition constant: 2400 nM
Compound 3: middle estimate off by 1.7-fold (0.22 log units), on the high side; the range from low to high includes it.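

This position, on an aromatic carbon of the fused system and ortho to a hydroxy group, now has its first measured change: hydroxy in place of hydrogen gives a 1.9-fold lower number from compound 2 to compound 3 (0.28 log units; within the scatter) in this assay. The position therefore accepts a second hydroxy group with no change that can be told from the scatter, so compound 2 and compound 3 stand as equals in this read-out, and the earlier step on the pendant phenyl ring could not have shown this. Nothing among the data shown gives a reason for this result, and a single substitution at this position supports no trend.

The compounds shown leave open whether the position stays as accepting with a group other than hydroxy, such as methoxy, an amine or a carboxylic acid, or whether a larger change here would move the number beyond the scatter. They also leave open whether the second hydroxy group would change the outcome when a bromo group sits on the pendant phenyl ring, as it does in compound 1.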